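Ester to propargyl amide on an inactive core

The source may report more compounds than this note shows. Statements on the series, on what has been measured and on what is new or still open speak of the compounds shown alone.

Measured in a functional assay on HCT-116 cells (Homo sapiens) for cytotoxicity, with a stated time of 3 days; a lower number here means a stronger inhibitor, a higher number a weaker inhibitor:
Compound 1 `C=Cc1nc(C(=O)OCC)cs1`: > 40000 nM
Compound 2 `C#CCNC(=O)c1csc(C#Cc2ccccc2)n1`: > 40000 nM
Compound 3 `C#Cc1nc(C(=O)OCC)cs1`: > 40000 nM

All three entries are limits of the assay and not numbers, and the series offers no measured potency to rank: the limit of > 40000 nM in this assay, at which 3 of the 3 values shown sit. Compound 3 stands at > 40000 nM, which is a limit.

The next compound, compound 4 `C#CCNC(=O)c1csc(C#C)n1`, has not yet been measured. It differs from compound 3 by one change, propargylamino in place of ethoxy on a carbonyl carbon.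

Only one measured step links two of these compounds, a step that the two limits leave unreadable from compound 1 to compound 3. That step is ethynyl in place of vinyl on an aromatic carbon, so it does not concern the carbonyl substituent, and it has no readable size. Compound 2 already carries the propargylamino group, and its > 40000 nM is again a limit. Nothing measured therefore gives a size or direction for the change in this assay, and no step beyond the scatter is expected on this evidence.

The step expected on this reasoning is a number no higher from compound 3 to compound 4 (the limit leaves the size open). For compound 4 the estimated value is 40000 nM, with an expected range from 12000 nM to 80000 nM.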

Compound 4, half-maximal inhibitory concentration: 19200 nM
For compound 4 the middle estimate is 2.1-fold (0.32 log units) above the measured one, and the stated range covers the measured number.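

In this assay, for the compounds shown here, propargylamino in place of ethoxy on a carbonyl carbon gives an at least 2.0-fold lower number from compound 3 to compound 4 (0.31 log units; beyond the scatter), the first step with a readable direction and the first sign that this carbonyl substituent matters on the shared core. The same propargylamino group does not by itself bring a measured potency: hydrogen in place of phenyl on a triple-bonded carbon gives an at least 2.0-fold lower number from compound 2 to compound 4 (0.31 log units; beyond the scatter), so the number appears only with both the amide and the unsubstituted triple-bonded carbon present. Each step starts from a limit, so its printed size is only a lower bound. Going by these compounds alone, compound 4 gives 19200 nM, the only measured number. The other compounds all share one entry: the limit of > 40000 nM in this assay, at which 3 of the 4 values shown sit.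

Going by these compounds, what remains open is whether the step belongs to the amide itself or to the triple bond within propargylamino, which a propylamino or methylamino group on the carbonyl carbon, or a carboxylic acid there, would help to separate. On these data alone, it is also open how much room the triple-bonded carbon allows, since a methyl or a hydroxymethyl group there would fall between hydrogen and phenyl.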